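Benzothiazolyl-aminopyrimidine sulfonyl anilines: fluoro to methyl swap

The source may hold more compounds than are shown below. What is called first, only, known or untested is meant among the compounds shown, and "the series" means these compounds.

Measured compounds:
compound 1 `CS(=O)(=O)c1ccc(Nc2ncc(F)c(Nc3nc4ccccc4s3)n2)cc1`, 4980 nM
compound 2 `Cc1ccc2nc(Nc3nc(Nc4ccc(S(N)(=O)=O)cc4)ncc3F)sc2c1`, 6390 nM
compound 3 `Cc1ccc2nc(Nc3nc(Nc4ccc(S(N)(=O)=O)cc4)ncc3C)sc2c1`, 9080 nM

Notes. In a functional assay on MDA-MB-231 cells (Homo sapiens) for antiproliferative activity, read by MTT assay, with a stated time of 48 h (a higher number here means a weaker inhibitor, a lower number a stronger inhibitor), compound 1 gives 4980 nM. Among the three numbers compound 1 sits at one end, with compound 2 nearest and compound 3 furthest; both gaps are within the scatter. Compound 4 `Cc1cnc(Nc2ccc(S(C)(=O)=O)cc2)nc1Nc1nc2ccccc2s1` arises from compound 1 by methyl in place of fluoro on an aromatic carbon. The same exchange is already on record once, as a 1.4-fold higher number from compound 2 to compound 3 (0.15 log units; within the scatter), a move within the scatter. On that basis no change beyond the scatter is expected from compound 1 to compound 4 in this assay, and the expected step is a 1.2-fold higher number from compound 1 to compound 4 (0.08 log units; within the scatter). Compound 4 is therefore estimated at 6000 nM, in the range 3000 nM to 12000 nM.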

Compound 4, half-maximal inhibitory concentration: 14800 nM
For compound 4 the middle estimate is 2.5-fold (0.39 log units) below the measured one; measured number above the stated range.
By their numbers in this assay, from the lowest: compounds 1, 2, 3 and 4 (each within the scatter of the next, the first and the last beyond it).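

In this assay, methyl in place of fluoro on this aromatic carbon of the core of compound 1 now gives a step that can be read: a 3.0-fold higher number from compound 1 to compound 4 (0.47 log units; beyond the scatter). The earlier pair alone had shown no step beyond the scatter for this change. The gap between the two steps does not separate the cores, so no dependence on the core can be claimed: the same change on two cores in this assay, a 1.4-fold higher number (0.15 log units; within the scatter) from compound 2 to compound 3 and a 3.0-fold higher number (0.47 log units; beyond the scatter) from compound 1 to compound 4, 2.1-fold (0.32 log units) apart, within the scatter of two such steps

The compounds shown leave open how chloro, an amine or a longer chain such as ethyl would read on this aromatic carbon.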